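The source may report more compounds than this note shows. Statements on the series, on what has been measured and on what is new or still open speak of the compounds shown alone.

Among the measured compounds shown here, compound 1 `CC(=O)OC/C(=C\c1ccccc1[N+](=O)[O-])C(=O)c1ccccc1` is the first of three measured compounds. In a functional assay on T47D cells (Homo sapiens) for inhibition, read by sulforhodamine B assay, with a stated time of 48 h (on this read-out higher numbers stand for weaker inhibition of growth and lower numbers for stronger inhibition of growth), compound 1 gives 21000 nM. Compound 2 `O=C(OC/C(=C\c1ccccc1[N+](=O)[O-])C(=O)c1ccccc1)c1ccccc1` differs from it in one place phenyl in place of methyl on a carbonyl carbon and in this assay compound 2 gives 16000 nM; the step of a 1.3-fold lower number from compound 1 to compound 2 (0.12 log units; within the scatter). Compound 3 `CC(=O)OC/C(=C/c1ccc(Cl)cc1Cl)C(=O)c1ccccc1` is built on another core, and how its core differs from that of compound 1 is not broken down here. In this assay compound 3 gives 20000 nM, and its value and those of compound 1 and compound 2 all lie within the scatter of one another, so no order among the three can be read.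

Compound 4 `O=C(OC/C(=C/c1ccc(Cl)cc1Cl)C(=O)c1ccccc1)c1ccccc1` has not yet been measured. It differs from compound 3 in one place (phenyl in place of methyl on a carbonyl carbon), the same change that separates compound 1 from compound 2, at a place that reads word for word the same. The step from compound 3 to compound 4 is expected to be a 1.3-fold lower number from compound 3 to compound 4 (0.12 log units; within the scatter), resting on the step of a 1.3-fold lower number from compound 1 to compound 2 (0.12 log units; within the scatter) which stayed within the scatter. Compound 4 is accordingly estimated to give 15000 nM in this assay, with an expected range from 7000 nM to 35000 nM.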

Compound 4, concentration for 50% growth inhibition: 5400 nM
Compound 4: the middle estimate sits 2.8-fold (0.44 log units) above what was measured; measured number outside the range, below it.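

In this assay, phenyl in place of methyl on a carbonyl carbon gives a 3.7-fold lower number from compound 3 to compound 4 (0.57 log units; beyond the scatter), so the change does not carry over at one size from the core of compound 1 to the core of compound 3: the same change on two cores in this assay, a 1.3-fold lower number (0.12 log units; within the scatter) from compound 1 to compound 2 and a 3.7-fold lower number (0.57 log units; beyond the scatter) from compound 3 to compound 4, 2.8-fold (0.45 log units) apart, beyond the scatter of two such steps. The swap from acetoxy to benzoyloxy therefore cannot be treated as a fixed increment in this series, since what it delivers on one core did not predict what it delivered on the other. These two pairs do not show which difference between the cores goes with the larger step, and they give no rule for any further core.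

The compounds shown leave open whether a longer chain, such as propyl, or an amine on the same carbonyl carbon would follow the phenyl or the methyl result on either core. They also leave open whether a carboxylic acid in the place of the phenyl would show the same dependence on the core.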